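Three hydroxyphenyl pyridines at the limit; a trifluoromethyl variant

The source may report more compounds than this note shows. Statements on the series, on what has been measured and on what is new or still open speak of the compounds shown alone.

Compound 1 `Oc1ccccc1-c1cc(-c2ccc(F)cc2)cc(-c2ccccc2O)n1` gives > 50000 nM in a functional assay on HCT-15 cells (Homo sapiens) for inhibition (a lower number here means a stronger inhibitor, a higher number a weaker inhibitor), which is a limit of the assay rather than a number.
Compound 2 `Oc1cccc(-c2cc(-c3ccc(F)cc3)cc(-c3ccccc3O)n2)c1` gives > 50000 nM, again a limit.
Compound 3 `Oc1ccc(-c2cc(-c3ccc(F)cc3)cc(-c3ccccc3O)n2)cc1` gives > 50000 nM, also a limit.

Compound 3 therefore stands nowhere that can be pinned down on the numbers shown: all three measured compounds rest on the same limit, (the limit of > 50000 nM in this assay, at which 3 of the 3 values shown sit). The steps among them, a step that the two limits leave unreadable from compound 1 to compound 2, a step that the two limits leave unreadable from compound 1 to compound 3 and a step that the two limits leave unreadable from compound 2 to compound 3, are unreadable for the same reason, so moving the hydroxyl around the phenyl ring gives no readable change.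

Compound 4 `Oc1ccc(-c2cc(-c3ccccc3C(F)(F)F)cc(-c3ccccc3O)n2)cc1` differs from compound 3 in one place: 2-(trifluoromethyl)phenyl in place of 4-fluorophenyl on an aromatic carbon. Going by the values given here, no measured step bears on this exchange, and the only evidence is that every compound so far sits at the limit. The expected step that the limit leaves unreadable from compound 3 to compound 4 is therefore none that can be read, and compound 4 is expected at 60000 nM, within 20000 nM to 200000 nM, most likely again as a limit.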

Compound 4, half-maximal inhibitory concentration: 8990 nM
For compound 4 the middle estimate is 6.7-fold (0.82 log units) above the measured one; the measured number lies below the stated range.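

Going by these compounds alone, compound 4 is the only one of the four compounds with a measured number rather than a limit, and the earlier changes, which only moved a hydroxyl around a phenyl ring, gave no step that can be read. In this assay, placing 2-(trifluoromethyl)phenyl instead of 4-fluorophenyl on the aromatic carbon opposite the ring nitrogen gives an at least 5.5-fold lower number from compound 3 to compound 4 (0.74 log units; beyond the scatter), so a change at this place can bring a readable inhibition. That figure is only a minimum for the step, because compound 3 rests on a limit: the limit of > 50000 nM in this assay, at which 3 of the 4 values shown sit.

The compounds shown do not separate the arrival of the trifluoromethyl group from the loss of the fluorine, and a methoxy group or a chlorine on that ring would be among the next groups to compare. From the compounds shown here alone, it also remains open whether the same exchange gives a readable step with the hydroxyl arrangements of compound 1 and compound 2.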